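Swapping phenyl for phenoxy on the saturated ring

The compounds below may be only part of what the source reports. "The series", "measured", "known", "first", "only" and "open" are said of these compounds alone.

Compound 1 `O=C(CCC1CCC(c2ccccc2)CC1)N1CCCC1` was tested in an assay on HEK293 cells for inhibition of Fatty-acid amide hydrolase 1 (Rattus norvegicus), read by LC-MS, with a stated time of 30 min (a higher number here means a weaker inhibitor, a lower number a stronger inhibitor), and gave 66000 nM. Compound 2 `O=C(CCc1ccc(Oc2ccccc2)cc1)N1CCCC1` gave 120000 nM in this assay, and the gap between these two values lies within the scatter of the measurement. Compound 3 `O=C(CCC1CCC(Oc2ccccc2)CC1)N1CCCC1` has not been measured yet; it differs from compound 1 by phenoxy in place of phenyl on a saturated ring carbon. Among the measured compounds shown here, no measured pair shows this exact change, so for this assay no step beyond the scatter is expected, in either direction. Compound 3 is therefore estimated at 80000 nM, with a likely range from 30000 nM to 250000 nM, meaning an expected step of a 1.2-fold higher number from compound 1 to compound 3 (0.08 log units; within the scatter).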

Compound 3, half-maximal inhibitory concentration: 45100 nM
Beside the measured number, compound 3's estimate is 1.8-fold (0.25 log units) above it; the measured number falls inside the stated range.
By their numbers in this assay, from the lowest: compounds 3, 1 and 2 (each within the scatter of the next, the first and the last beyond it).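

On the saturated ring carbon, phenoxy in place of phenyl gives a 1.5-fold lower number from compound 1 to compound 3 (0.17 log units; within the scatter) in this assay. This position therefore accepts the extra oxygen, with its one hydrogen-bond acceptor, without a step beyond the scatter. No separate measurement bears on why the two groups read alike. Still open, from the compounds shown here alone, is whether a group of another kind on this ring carbon, such as an amine or a carboxylic acid, would move the number beyond the scatter. A longer chain in place of phenoxy remains equally untested in the compounds shown.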